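This account rests on a few compounds, and the source may have more. Where it says the series, first, only, none or still open, it means among the compounds named here.

Compound 1 `O=C(O)c1cnc(-c2ccccc2F)[nH]c1=O` gives 5 mg/kg in a functional assay on the whole organism (strain Sprague-Dawley) for inhibition, with Rattus norvegicus as the target, with a stated time of 10 min; on this read-out lower numbers stand for an effect already at smaller amounts and higher numbers for an effect only at larger amounts of compound. Compound 2 `CCOC(=O)C(=O)Nc1ccc(OCC)c(-c2ncc(C(=O)O)c(=O)[nH]2)c1` gives 25 mg/kg in this assay. For compound 3 `CCOC(=O)c1cnc(-c2ccccc2F)[nH]c1=O` the read-out is only a limit, > 10 mg/kg. Compound 3 thus stands at the limit of > 10 mg/kg in this assay, at which 1 of the 3 values shown sits. The step of an at least 2.0-fold higher number from compound 1 to compound 3 (0.30 log units; that floor lies within the scatter) comes from ethyl in place of hydrogen on an oxygen next to a carbonyl group. Compound 4 `CCOC(=O)c1cnc(-c2ccccc2SC)[nH]c1=O` differs from compound 3 by methylsulfanyl in place of fluoro on an aromatic carbon. Among the measured compounds shown here, no measured step touches this change, so no step beyond the scatter is expected, and compound 4 is estimated to sit near the limit of compound 3, giving 20 mg/kg, between 8 mg/kg and 60 mg/kg. The expected step is a step that the limit leaves unreadable from compound 3 to compound 4.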

Compound 4, dose for 50% inhibition: > 25 mg/kg
Compound 4: a limit, no number; the forecaster's own chance of this, stated with the estimate: 50%; middle value at least 1.2-fold (0.09 log units) away from the limit.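

Among the compounds shown here, compound 3 and compound 4 each carry only a limit in this assay, so no step between them can be read. The compounds shown leave open whether methylsulfanyl in place of fluoro on an aromatic carbon changes the read-out at all.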